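Shortening the ester chain from compound 2 to compound 4

The source may report more compounds than this note shows. Statements on the series, on what has been measured and on what is new or still open speak of the compounds shown alone.

Compound 2 `CCCCOC(=O)CCCc1cc(CN2CCCC2)c(O)c(CN2CCCC2)c1` gives 0.33 ug/mL in a functional assay for inhibition, with Cavia porcellus as the target (a lower number here means that less compound is needed, a higher number that more compound is needed for the effect), the lowest number among the measured values, and compound 1 `CCCOC(=O)CCc1cc(CN2CCCC2)c(O)c(CN2CCCC2)c1` gives 7 ug/mL. Compound 3 `O=C(O)CCc1cc(CN2CCCC2)c(O)c(CN2CCCC2)c1` gives only a limit in this assay, > 1000 ug/mL, not a number (the limit of > 1000 ug/mL in this assay, at which 1 of the 3 values shown sits). Both measured steps are large: a 21-fold lower number from compound 1 to compound 2 (1.33 log units; beyond the scatter) and an at least 3000-fold higher number from compound 2 to compound 3 (3.48 log units; beyond the scatter). Compound 4 `CC(C)OC(=O)CCc1cc(CN2CCCC2)c(O)c(CN2CCCC2)c1` differs from compound 2 by isopropoxycarbonyl in place of (butoxycarbonyl)methyl on a saturated chain carbon, two bonds along the chain from an aromatic carbon. The change largely reverses the step from compound 1 to compound 2 while keeping an ester, so the large step of an at least 140-fold higher number from compound 1 to compound 3 (2.15 log units; beyond the scatter) toward the free acid should not apply. Compound 4 is therefore expected to give about 8 ug/mL, within 2 ug/mL to 30 ug/mL. The expected step is a 24-fold higher number from compound 2 to compound 4 (1.38 log units; beyond the scatter), a higher number.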

Compound 4, concentration for half-maximal effect: 4 ug/mL
Compound 4: the middle estimate sits 2.0-fold (0.30 log units) above what was measured; the range from low to high includes it.
By their numbers in this assay, from the lowest: compound 2; then compounds 4 and 1 (each within the scatter of the next). At a limit, above all of these: compound 3.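

In this assay, the isopropyl and propyl esters are not separated, with a 1.8-fold lower number from compound 1 to compound 4 (0.24 log units; within the scatter). Compound 2 stays apart from this second short ester, with a 12-fold higher number from compound 2 to compound 4 (1.08 log units; beyond the scatter), so its low number is not tied to the propyl ester alone. Branched or straight, the short ester also stands far from the free acid, with an at least 250-fold lower number from compound 3 to compound 4 (2.39 log units; beyond the scatter), though that step starts from a limit and not a number: the limit of > 1000 ug/mL in this assay, at which 1 of the 4 values shown sits.

Compound 2 differs on both sides of the carbonyl, so the longer chain before the carbonyl and the butyl on the oxygen remain unseparated. On these data alone, how an amide in place of the ester would read also stays open.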